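The compounds below may be only part of what the source reports. "The series", "measured", "known", "first", "only" and "open" are said of these compounds alone.

Measured so far:
compound 1, `C[N+](C)(CCCC(=O)[O-])C1CCC1`, in an assay for inhibition of gamma-butyrobetaine dioxygenase (Homo sapiens), read by HPLC, with stated times of 15 min and 30 min (on this read-out higher numbers stand for weaker inhibition and lower numbers for stronger inhibition), compound 1 gives 810 nM.
compound 2, `CCC[N+](C)(C)CCCC(=O)[O-]`, in this assay compound 2 gives > 1000000 nM, which is a limit of the assay and not a number.

Compound 2 therefore stands at the edge of what this assay can report, as the limit of > 1000000 nM in this assay, at which 1 of the 2 values shown sits, records. Among the compounds with values here, the only measured step, an at least 1200-fold higher number from compound 1 to compound 2 (3.09 log units; beyond the scatter), led to that limit. Compound 3, `C#CC[N+](C)(C)CCCC(=O)[O-]`, differs from compound 2 by ethynyl in place of ethyl on a saturated chain carbon bound to an amine nitrogen. Within the data shown here, no measured step concerns the ethyl-to-ethynyl exchange itself, so the single large step from compound 1 to compound 2 gives no direct guide to its direction. With compound 2 known only as a limit, the step from compound 2 to compound 3 in this assay is expected to be small or unresolved, an at least 2.0-fold lower number from compound 2 to compound 3 (0.30 log units; that floor lies within the scatter), and a further limit is thought the most likely outcome. Compound 3 is accordingly estimated at 500000 nM in this assay, within a range from 30000 nM to 5000000 nM.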

Compound 3, half-maximal inhibitory concentration: 1400 nM
Estimate against measurement, compound 3: 360-fold (2.55 log units) above, and the stated range ends above it.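

At this place, on a saturated chain carbon bound to an amine nitrogen, the change from ethyl to ethynyl alone decides the outcome: in this assay, ethynyl in place of ethyl gives an at least 710-fold lower number from compound 2 to compound 3 (2.85 log units; beyond the scatter). Cyclobutyl is thus not the only group on this nitrogen that gives a low number, since propargyl in place of cyclobutyl gives a 1.7-fold higher number from compound 1 to compound 3 (0.24 log units; within the scatter), and the two cannot be told apart here. Compound 2 remains a limit of the assay and not a number, so the true size of any step from it stays unknown: the limit of > 1000000 nM in this assay, at which 1 of the 3 values shown sits.

The compounds shown leave open whether an allyl group, with a double bond in place of the triple bond, would read like propargyl or like propyl. They also leave open how a longer butynyl chain would read.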